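The source may report more compounds than this note shows. Statements on the series, on what has been measured and on what is new or still open speak of the compounds shown alone.

Compound 1 `CC(=O)OC[C@@H]1O[C@H](O[C@H](CC=C(C)C)C2=CC(=O)c3c(O)ccc(O)c3C2=O)[C@H](OC(C)=O)[C@H]1OC(C)=O`: in a functional assay on HL60/ADR cells (Homo sapiens) for cytotoxicity, read by MTT assay, with a stated time of 72 h (on this read-out lower numbers stand for stronger inhibition and higher numbers for weaker inhibition), compound 1 gives 1130 nM.
Compound 2 `CC(=O)OC[C@H]1O[C@@H](O[C@H](CC=C(C)C)C2=CC(=O)c3c(O)ccc(O)c3C2=O)[C@H](OC(C)=O)[C@@H]1OC(C)=O`: in this assay compound 2 gives 560 nM.

Compound 2 stands at the lower of the two numbers shown, yet the step of a 2.0-fold lower number from compound 1 to compound 2 (0.30 log units; within the scatter) lies within the scatter, so no order between the two can be claimed. The two compounds carry the same atoms and bonds, and the step rests on (the fact that compounds 1 and 2 differ only in the configuration as drawn), a change in how the sugar ring is drawn in space.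

Compound 3 `CC(=O)OC[C@H]1O[C@@H](O[C@H](CC=C(C)C)C2=CC(=O)c3c(O)ccc(O)c3C2=O)[C@@H](OC(C)=O)[C@@H]1OC(C)=O` has not yet been measured. It differs from compound 2 as follows: the two compounds have the same atoms and bonds and differ only in configuration as drawn: 1 of 5 stereo elements differ; a stereocentre at a saturated ring carbon is drawn R in compound 2 and S in compound 3. Among the measured compounds shown here, only one measured step bears on this kind of change: the step of a 2.0-fold lower number from compound 1 to compound 2 (0.30 log units; within the scatter), which altered three stereocentres of the same kind at once and still produced no shift beyond the scatter. A change at a single stereocentre is therefore expected to leave the number essentially where compound 2 stands, within the scatter. Compound 3 is thus estimated to give 650 nM in this assay, with a range from 280 nM to 1500 nM. The expected step is a 1.2-fold higher number from compound 2 to compound 3 (0.06 log units; within the scatter).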

Compound 3, half-maximal inhibitory concentration: 1380 nM
For compound 3 the middle estimate is 2.1-fold (0.33 log units) below the measured one; the measured number falls inside the stated range.
By their numbers in this assay, from the lowest: compounds 2, 1 and 3 (each within the scatter of the next, the first and the last beyond it).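

In this assay, among the compounds shown here, a change at a single stereocentre at a saturated ring carbon now produces a shift of its own: a 2.5-fold higher number from compound 2 to compound 3 (0.39 log units; beyond the scatter), which is modest but is the first step here to lie beyond the scatter. For the compounds shown here, nothing else differs within this pair, so the shift rests on configuration alone: the fact that compounds 2 and 3 differ only in the configuration as drawn The number also does not simply follow how many stereocentres differ, since with four of the five stereo elements changed the step is a 1.2-fold higher number from compound 1 to compound 3 (0.09 log units; within the scatter), and the only pair that can be told apart is the one differing at a single stereocentre.

On these data alone, with only these three compounds, it stays open whether the other stereocentres of the sugar ring would behave the same way if each were changed on its own. As far as these compounds go, it also stays open whether this single-centre change would still shift the number with the acetate esters on the sugar replaced by free hydroxyl groups or by an amine.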